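This account rests on a few compounds, and the source may have more. Where it says the series, first, only, none or still open, it means among the compounds named here.

Of the compounds shown here, three from this set have been measured in an assay on membranes from brain with Neuronal acetylcholine receptor; alpha4/beta2 (Rattus norvegicus) as the target; a higher number here means a weaker inhibitor, a lower number a stronger inhibitor. Compound 1, `Clc1ncc(OC[C@@H]2CCN2)cc1/C=C/c1ccncc1`, gives 0.009 nM. Compound 2, `Clc1ncc(OC[C@@H]2CCN2)cc1-c1cccnc1`, gives 0.0081 nM in this assay; the difference between the core of compound 1 and the core of compound 2 is not broken down here. Compound 3, `Fc1ccc(-c2cc(OC[C@@H]3CCN3)cnc2Cl)cn1`, gives 0.0049 nM in this assay. All three numbers lie close together, and none of the gaps between them goes beyond what repeated measurements of this kind usually show.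

Compound 3 arises from compound 2 by one change, (fluoro in place of hydrogen on an aromatic carbon), and that change made a step of a 1.7-fold lower number from compound 2 to compound 3 (0.22 log units; within the scatter).

Compound 4, `Fc1cc(/C=C/c2cc(OC[C@@H]3CCN3)cnc2Cl)ccn1`, has not yet been measured. It arises from compound 1 by fluoro in place of hydrogen on an aromatic carbon. Within the data shown here, this is the same kind of change as the one from compound 2 to compound 3, though the surroundings differ: in compound 3 the fluoro sits para to a large group, in compound 4 it sits meta to a large group.

Among the measured compounds shown here, the step expected from compound 1 to compound 4 in this assay is a 1.5-fold lower number from compound 1 to compound 4 (0.18 log units; within the scatter), resting on the only comparable change in this set, which gave a 1.7-fold lower number from compound 2 to compound 3 (0.22 log units; within the scatter). Compound 4 is therefore estimated at 0.006 nM, with a likely range from 0.002 nM to 0.02 nM.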

Compound 4, inhibition constant: 0.0031 nM
Compound 4: middle estimate off by 1.9-fold (0.29 log units), on the high side; the range from low to high includes it.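

In this assay, turning pyridin-4-yl into 2-fluoropyridin-4-yl gives a 2.9-fold lower number from compound 1 to compound 4 (0.46 log units; beyond the scatter), a modest but readable step toward stronger binding. Set beside the earlier case, the same change points the same way on both cores, and the sizes of the two steps cannot be told apart: the same change on two cores in this assay, a 1.7-fold lower number (0.22 log units; within the scatter) from compound 2 to compound 3 and a 2.9-fold lower number (0.46 log units; beyond the scatter) from compound 1 to compound 4, 1.8-fold (0.24 log units) apart, within the scatter of two such steps This supports carrying the change from one core to another in this series as a small move toward a lower number, but it rests on only two pairs, and only one of those steps clears the scatter, so it does not show that the step is truly larger on one core than on the other, or that it would hold on a third core.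

Among the compounds shown, only hydrogen and fluoro appear at this place, so it remains open whether a methyl, a methoxy or an amine there would shift the number in the same direction, or by a similar amount. Also open, going by these compounds, is whether the lower number seen in this assay would carry over to any other receptor or read-out, as these compounds are compared in this single binding measurement.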